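The source may hold more compounds than are shown below. What is called first, only, known or untested is meant among the compounds shown, and "the series" means these compounds.

Compound 2 `COc1cc(-c2nnc3n2NC(c2ccco2)C(C(=O)c2ccc([N+](=O)[O-])cc2)S3)cc(OC)c1OC` is, so far, the compound with the lowest number in a functional assay on PC-3 cells (Homo sapiens) for cytotoxicity, read by MTT assay, with a stated time of 48 h (on this read-out higher numbers stand for weaker inhibition and lower numbers for stronger inhibition), where compound 2 gives 27900 nM. Its nearest neighbour is compound 1 `COc1cc(-c2nnc3n2NC(c2ccco2)C(C(=O)C2CC2)S3)cc(OC)c1OC`, which in this assay gives 95200 nM. Within the data shown here, the one step recorded between them is a 3.4-fold lower number from compound 1 to compound 2 (0.53 log units; beyond the scatter), in which 4-nitrophenyl replaced cyclopropyl on a carbonyl carbon. Compound 3 `COc1cc(-c2nnc3n2NC(c2ccco2)C(C(=O)c2ccc(-c4ccccc4)cc2)S3)cc(OC)c1OC` differs from compound 2 in a single place: phenyl in place of nitro on an aromatic carbon. The measured step from compound 1 to compound 2 concerns the same carbonyl substituent, but it exchanged a ring for a different ring, whereas the present change swaps one substituent on that ring for another; it therefore gives only a loose hint of direction and none of size. Among the measured compounds shown here, with no step of this kind measured, the expectation for compound 3 is a number close to that of compound 2, the estimated step being a 1.1-fold lower number from compound 2 to compound 3 (0.05 log units; within the scatter), within the scatter. Compound 3 is expected to give about 25000 nM in this assay, within a range from 8000 nM to 80000 nM.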

Compound 3, half-maximal inhibitory concentration: 45900 nM
Estimate against measurement, compound 3: 1.8-fold (0.26 log units) below, within the range that was stated.
By their numbers in this assay, from the lowest: compounds 2 and 3 (each within the scatter of the next); then compound 1.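

In this assay, the change from 4-nitrophenyl to 4-phenylphenyl gives a 1.6-fold higher number from compound 2 to compound 3 (0.22 log units; within the scatter), so at this place on the aromatic ring a phenyl group, made of carbon only, stands in for nitro with no difference that can be told from the scatter. The exchange of cyclopropyl on the carbonyl carbon for 4-phenylphenyl gives a 2.1-fold lower number from compound 1 to compound 3 (0.32 log units; beyond the scatter), a modest step in the same direction as the one to 4-nitrophenyl, so the lower number seen earlier does not depend on the nitro group itself, though this step lies only just beyond the scatter. Nothing available explains either step, and no measurement bears on the result.

The compounds shown leave open whether the ring needs a group at this place at all, since a plain phenyl on the carbonyl carbon is not among them, and so the share of the ring and of its substituent in the step from cyclopropyl cannot be separated. They also leave open whether an amine, a carboxylic acid or a methoxy group here would move the number clearly away from that of compound 2, which gives 27900 nM.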